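The source may hold more compounds than are shown below. What is called first, only, known or untested is meant among the compounds shown, and "the series" means these compounds.

Compound 1, with the structure `CCCc1nc(C)c2c(C)nn(CC)c(=O)n12`, is the starting point of this comparison. In a functional assay for inhibition, with Homo sapiens as the target (a higher number here means a weaker inhibitor, a lower number a stronger inhibitor), compound 1 gives only a limit, reported as > 48000 nM. Its close relative compound 3, with the structure `CCCc1nc(C)c2cnn(CC)c(=O)n12`, likewise gives only a limit, > 48000 nM. The third measured compound, compound 2, with the structure `Cc1ncn2c(NCc3ccco3)nncc12`, also returns a limit, > 48000 nM. Among the compounds with values here, the one step between measured compounds that differ in one place is a step that the two limits leave unreadable from compound 1 to compound 3, a change of hydrogen in place of methyl on an aromatic carbon, and because both ends sit at a limit its size cannot be read; indeed the limit of > 48000 nM in this assay, at which 3 of the 3 values shown sit, describes all that the measured compounds show.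

Compound 4, with the structure `CCCc1nc(C)c2c(C)nn(CC(=O)OCC)c(=O)n12`, differs from compound 1 by ethoxycarbonyl in place of methyl on a saturated chain carbon bound to an aromatic nitrogen. Within the data shown here, no measured step touches this position or this group, so nothing among the measured steps bears on it, and the change is taken with no expected direction beyond the scatter. The estimate for compound 4 is 60000 nM, within 20000 nM to 200000 nM. The step this estimate means, a step that the limit leaves unreadable from compound 1 to compound 4, is expected to be essentially none beyond the scatter, with a limit again the most likely outcome.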

Compound 4, half-maximal inhibitory concentration: > 48000 nM
Compound 4: no number, only a limit; the forecaster's own chance of this, stated with the estimate: 80%; the middle value lies beyond the limit too.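

In this assay compound 4 also gives only a limit, > 48000 nM. With compound 1 likewise at a limit, the step between compound 1 and compound 4 cannot be read. The compounds shown leave open how strongly any of them inhibits and what any single change does to that inhibition: the limit of > 48000 nM in this assay, at which 4 of the 4 values shown sit.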